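This account rests on a few compounds, and the source may have more. Where it says the series, first, only, none or still open, it means among the compounds named here.

Measured so far:
compound 1 `O=C(Nc1cccc2cccnc12)c1ccc(Br)cn1` — 4000 nM
compound 2 `Cc1cnc(C(=O)Nc2ccc3ncccc3c2)cn1` — > 10000 nM
compound 3 `Cc1cnc(C(=O)Nc2ccc(Br)c3cccnc23)cn1` — 6800 nM

In a functional assay on PANC-1 cells (Homo sapiens) for inhibition, read by MTT assay, with a stated time of 72 h (a lower number here means a stronger inhibitor, a higher number a weaker inhibitor), compound 1 gives 4000 nM. Compound 2 reaches only a limit of the assay, > 10000 nM, and not a number; this is the limit of > 10000 nM in this assay, at which 1 of the 3 values shown sits. Compound 3 gives 6800 nM, the higher of the two numbers recorded here; the nearest value is that of compound 1, and the gap between them lies within the scatter, so no order between compound 1 and compound 3 can be set.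

Compound 4 `O=C(Nc1ccc(Br)c2cccnc12)c1cnccn1` differs from compound 3 in one place: hydrogen in place of methyl on an aromatic carbon. For the measured compounds named here, no measured pair shows this change on its own. Compound 2 carries the same 5-methylpyrazin-2-yl amide on another core and stops at a limit, so it fixes no size for the share of the methyl. With nothing to go on beyond the three values, the change is expected to give a step from compound 3 to compound 4 of a 1.0-fold higher number from compound 3 to compound 4 (0.01 log units; within the scatter), which is not expected to exceed the scatter in either direction. Compound 4 is therefore estimated at 7000 nM, with a range from 2500 nM to 20000 nM.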

Compound 4, half-maximal inhibitory concentration: 7000 nM
For compound 4 middle estimate and measured number coincide at the digits printed, and the stated range covers the measured number.
By their numbers in this assay, from the lowest: compounds 1, 3 and 4 (each within the scatter of the next). At a limit, above all of these: compound 2.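

In this assay, for the compounds shown here, the change from 5-methylpyrazin-2-yl to pyrazin-2-yl can now be read on its own for the first time, with the rest of the molecule held constant: hydrogen in place of methyl on this aromatic carbon, next to the ring nitrogen, gives a 1.0-fold higher number from compound 3 to compound 4 (0.01 log units; within the scatter). On this core, then, the methyl makes no readable difference in this assay, and compound 4 gives 7000 nM without it. This rests on a single pair, so it describes this position on this core and sets no rule for the series. Compound 2 carries the same methyl-bearing amide on another core but stands at a limit and not a number, so it gives no second reading of this change: the limit of > 10000 nM in this assay, at which 1 of the 4 values shown sits.

Going by these compounds, it remains open whether the methyl would count on another core, where a measured pair with and without it would be needed. On these data alone, it also remains open whether a different group on the same aromatic carbon, such as an amine, a methoxy group or a longer chain, would move the number beyond the scatter.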